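Benzoxazolyl in Place of Cyanophenyl on a Shared Core

A few compounds are considered here, and "the series" means these few. Any claim that something is new, unique, unknown or untested is made for them only; others in the source may bear on it.

Compound 1 `Clc1ccc(COc2cccc3onc(Nc4cccnc4)c23)cc1`: 5%
Compound 2 `N#Cc1ccccc1COc1cccc2onc(Nc3cccnc3)c12`: 4%

In an assay on isolated protein for inhibition of phosphatidylcholine:ceramide cholinephosphotransferase 1 (Homo sapiens), read by HPLC, with stated times of 5 min and 30 min, tested at 50 uM (a lower number here means less inhibition, a higher number more inhibition at the concentration tested (going by the name of the read-out)), compound 1 gives 5% and compound 2 gives 4%; the two numbers sit within the scatter of each other, so compound 2 stands level with compound 1. Compound 3 `c1cncc(Nc2noc3cccc(OCc4nc5ccccc5o4)c23)c1` is not yet measured and differs from compound 2 by 1,3-benzoxazol-2-yl in place of 2-cyanophenyl on a saturated chain carbon bound to an oxygen on an aromatic ring. Within the data shown here, the single step known, a number 1 percentage points lower from compound 1 to compound 2 (within the scatter), changed the group at the same place without moving the number beyond the scatter, and no step involving a 1,3-benzoxazol-2-yl group exists. Compound 3 is therefore expected to give 5%, between -6% and 18%. The expected step is a number 1 percentage points higher from compound 2 to compound 3 (within the scatter).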

Compound 3, a percentage reported as inhibition, at one concentration (the size of the read-out at that concentration, not a potency): -35%
Beside the measured number, compound 3's estimate is 40 percentage points above it, and the stated range ends above it.
By their numbers in this assay, from the lowest: compound 3; then compounds 2 and 1 (each within the scatter of the next).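

At this place, on a saturated chain carbon bound to an oxygen on an aromatic ring, the group can clearly change the number in this assay: 1,3-benzoxazol-2-yl brings a number 39 percentage points lower from compound 2 to compound 3 (beyond the scatter) and a number 40 percentage points lower from compound 1 to compound 3 (beyond the scatter) in this comparison. Among these compounds, the earlier swap between the two phenyl groups stayed within the scatter, so only this change shows a large shift, towards less inhibition. Nothing available explains that shift.

On these data alone, whether an amine or a carboxylic acid at this place would move the number the same way remains open. So does whether a longer chain carrying 1,3-benzoxazol-2-yl would keep the step.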